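This account rests on a few compounds, and the source may have more. Where it says the series, first, only, none or still open, it means among the compounds named here.

Compounds measured so far in an assay on microsomes for inhibition of acyl-CoA:cholesterol acyltransferase (Oryctolagus cuniculus); a higher number here means a weaker inhibitor, a lower number a stronger inhibitor:
- compound 1 `CC(C)c1cccc(C(C)C)c1NC(=O)NCC1(c2cccc(N)c2)CCCC1`: 21 nM
- compound 2 `COC(=O)c1ccc(C2(CNC(=O)Nc3c(C(C)C)cccc3C(C)C)CCCC2)cc1`: 360 nM
- compound 3 `CC(C)c1cccc(C(C)C)c1NC(=O)NCC1(c2cccc(C(=O)O)c2)CCCC1`: 620 nM

Compound 3 gives the highest number of the three in this assay. Its nearest neighbour is compound 2, a 1.7-fold higher number from compound 2 to compound 3 (0.24 log units; within the scatter), so these two cannot be told apart. Compound 1 stands far away, a 30-fold higher number from compound 1 to compound 3 (1.47 log units; beyond the scatter), and the related move from the same starting point, a 17-fold higher number from compound 1 to compound 2 (1.23 log units; beyond the scatter), shows that both the carboxy and the methoxycarbonyl substitution carry a large cost next to the amino substitution in compound 1.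

Compound 4 `CC(C)c1cccc(C(C)C)c1NC(=O)NCC1(c2ccc(CO)cc2)CCCC1` arises from compound 3 by 4-(hydroxymethyl)phenyl in place of 3-carboxyphenyl on a saturated ring carbon. The step 2>3 bears on it most directly, since it also swaps one aryl substituent for another; it lay within the scatter. For the measured compounds named here, no measured step carries a hydroxymethyl group, so the change is largely unanchored. Some gain back toward compound 1 is expected but without support, so the step is estimated as a 3.4-fold lower number from compound 3 to compound 4 (0.54 log units; beyond the scatter). Compound 4 is expected at 180 nM, with a range from 40 nM to 700 nM.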

Compound 4, half-maximal inhibitory concentration: 26 nM
Estimate against measurement, compound 4: 6.9-fold (0.84 log units) above; measured number outside the range, below it.
By their numbers in this assay, from the lowest: compounds 1 and 4 (each within the scatter of the next); then compounds 2 and 3 (each within the scatter of the next).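

In this assay, the 4-(hydroxymethyl)phenyl group brings the number back down, with a 24-fold lower number from compound 3 to compound 4 (1.38 log units; beyond the scatter) and a 14-fold lower number from compound 2 to compound 4 (1.14 log units; beyond the scatter) as the two large steps; the second is a change of substituent alone, hydroxymethyl in place of methoxycarbonyl on an aromatic carbon. With a 1.2-fold higher number from compound 1 to compound 4 (0.09 log units; within the scatter) the pair cannot be told apart, so among these compounds a low number on the saturated ring carbon does not depend on 3-aminophenyl. No measurement at hand accounts for the size of these steps.

From the compounds shown here alone, compound 1 and compound 4 differ both in the group and in where it sits on the phenyl, so the share of each stays open. Going by these compounds, whether a methoxymethyl group or a longer chain such as hydroxyethyl would hold the low number also stays open.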